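The source may hold more compounds than are shown below. What is called first, only, known or untested is meant among the compounds shown, and "the series" means these compounds.

In a functional assay on MDA-MB-231 cells (Homo sapiens) for cytotoxicity, read by MTT assay, with a stated time of 72 h (a lower number here means a stronger inhibitor, a higher number a weaker inhibitor), compound 1 `CN(C)CCNc1nc(-c2ccc(NC(=O)Nc3ccccc3Cl)cc2)nc2ccsc12` gives 550 nM, compound 2 `CCN(CC)CCCNc1nc(-c2ccc(NC(=O)Nc3ccc(F)cc3)cc2)nc2ccsc12` gives 530 nM, and compound 3 `CCN(CC)CCCNc1nc(-c2ccc(NC(=O)Nc3ccc(Cl)cc3)cc2)nc2ccsc12` gives 230 nM. Among the measured compounds shown here, compound 3 has the lowest number of the three: the step of a 2.3-fold lower number from compound 2 to compound 3 (0.36 log units; beyond the scatter) is the only single change measured, and compound 1 stands at a higher number than compound 3 while differing from it in more than one place. Compound 4 `CCN(CC)CCCNc1nc(-c2ccc(NC(=O)Nc3ccccc3Cl)cc2)nc2ccsc12` differs from compound 3 by 2-chlorophenyl in place of 4-chlorophenyl on an amide-type nitrogen. For the measured compounds named here, no measured step tests that change directly; the one available step, a 2.3-fold lower number from compound 2 to compound 3 (0.36 log units; beyond the scatter), concerns a different exchange on the same ring. Compound 1 also carries the 2-chlorophenyl group, and its value of 550 nM sits above that of compound 3, though the two structures differ elsewhere as well. A modest rise in the number is therefore expected, as the step of a 2.0-fold higher number from compound 3 to compound 4 (0.29 log units; within the scatter), with wide uncertainty. Compound 4 is estimated in this assay at 450 nM, within a range from 200 nM to 1000 nM.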

Compound 4, half-maximal inhibitory concentration: 500 nM
The estimate for compound 4 lay 1.1-fold (0.05 log units) below the measured number; measured number inside the range.
By their numbers in this assay, from the lowest: compound 3; then compounds 4, 2 and 1 (each within the scatter of the next).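

In this assay, 2-chlorophenyl in place of 4-chlorophenyl on the amide-type nitrogen gives a 2.2-fold higher number from compound 3 to compound 4 (0.34 log units; beyond the scatter), so at this position the two isomeric groups are not interchangeable, although they hold the same atoms. 2-chlorophenyl in place of 4-fluorophenyl gives a 1.1-fold lower number from compound 2 to compound 4 (0.03 log units; within the scatter), so chlorine on this ring does not by itself give the lower number seen with 4-chlorophenyl. With 2-chlorophenyl held constant, the chain change gives a 1.1-fold lower number from compound 1 to compound 4 (0.04 log units; within the scatter), so this exchange of (diethylamino)methyl for dimethylamino is not resolved from the scatter.

Nothing available explains why the 4-chlorophenyl group gives the lower number. The compounds shown leave open how an unsubstituted phenyl or a 4-bromophenyl group on the same nitrogen would compare.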